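The source may report more compounds than this note shows. Statements on the series, on what has been measured and on what is new or still open speak of the compounds shown alone.

Compound 1 `COc1ccc(N(C)C(=O)N(C)c2cc(OC)c(OC)c(OC)c2)cc1`: >= 125000 nM
Compound 2 `COc1cc(NC(=O)Nc2ccc([N+](=O)[O-])cc2)cc(OC)c1OC`: 35000 nM
Compound 3 `COc1cc(N(C)C(=O)c2ccccc2)cc(OC)c1OC`: >= 125000 nM

In a functional assay on ONS-76 cells (Homo sapiens) for cytotoxicity, read by MTT assay, with a stated time of 72 h (a higher number here means a weaker inhibitor, a lower number a stronger inhibitor), compound 1 gives >= 125000 nM, which is a limit of the assay rather than a number. Compound 3 likewise gives >= 125000 nM, also a limit. For the measured compounds named here, compound 2 gives 35000 nM, the only value here that is a number. Going by the values given here, compound 1 therefore stands at the limit of >= 125000 nM in this assay, at which 2 of the 3 values shown sit, with no measured step leading from it to any other compound. Compound 4 `COc1cc(N(C)C(=O)N(C)c2cccc([N+](=O)[O-])c2)cc(OC)c1OC` differs from compound 1 by 3-nitrophenyl in place of 4-methoxyphenyl on an amide-type nitrogen. Because compound 2 gives 35000 nM as a number, a step towards a stronger inhibitor is expected from compound 1 to compound 4. The expected step of an at least 1.5-fold lower number from compound 1 to compound 4 (0.19 log units; that floor lies within the scatter) is modest. Compound 4 may still sit at a limit. For compound 4 the estimate is 80000 nM, ranging from 25000 nM to 125000 nM.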

Compound 4, half-maximal inhibitory concentration: >= 125000 nM
Compound 4: a limit, no number; the forecaster's own chance of this, stated with the estimate: 50%; middle value at least 1.5-fold (0.19 log units) away from the limit.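

In this assay, for the compounds shown here, compound 1 and compound 4 both give limits, not numbers, and no step between them can be read. From the compounds shown here alone, whether 3-nitrophenyl in place of 4-methoxyphenyl on an amide-type nitrogen changes the inhibition at all stays open.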